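Trimming the Ketone Side Chain in an Allosteric Modulator Series

This account rests on a few compounds, and the source may have more. Where it says the series, first, only, none or still open, it means among the compounds named here.

Measured compounds:
compound 1, `Cc1cc(C(=O)O)ccc1OCCCCOc1ccc(C(=O)CC(C)C)c(O)c1C`, gives 1850 nM in an assay on HEK293 cells for positive allosteric modulation of metabotropic glutamate receptor 3 (Rattus norvegicus), read by thallium flux, with a stated time of 2.5 min; a higher number here means that more compound is needed for the effect, a lower number that less compound is needed
compound 2, `COc1cc(C(=O)O)ccc1OCCCCOc1ccc(C(=O)CC(C)C)c(O)c1C`, gives 614 nM in this assay

Of the two measured compounds, compound 1 stands at the highest number in this assay; its nearest neighbour is compound 2, reached by a 3.0-fold lower number from compound 1 to compound 2 (0.48 log units; beyond the scatter), a change of methoxy in place of methyl on an aromatic carbon. Compound 3, `CCCC(=O)c1ccc(OCCCCOc2ccc(C(=O)O)cc2C)c(C)c1O`, differs from compound 1 instead by hydrogen in place of methyl on a saturated chain carbon bound to two saturated chain carbons, so the isobutylcarbonyl group becomes a propylcarbonyl group. For the measured compounds named here, no measured step touches this chain, and the single step from compound 1 to compound 2 concerns a different part of the molecule, so it offers no direct guide. With nothing known about the chain, the expectation for compound 3 is a step of a 1.4-fold higher number from compound 1 to compound 3 (0.13 log units; within the scatter), most likely inside the scatter. Compound 3 is therefore estimated at 2500 nM, in the range 900 nM to 7000 nM.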

Compound 3, half-maximal effective concentration: > 10000 nM
Compound 3: only a limit was reported; the forecaster's own chance of this, stated with the estimate: 15%; middle value at least 4.0-fold (0.60 log units) away from the limit.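

Removing a single methyl from the isobutylcarbonyl group, which leaves a propylcarbonyl group, gives an at least 5.4-fold higher number from compound 1 to compound 3 (0.73 log units; beyond the scatter) in this assay, so this chain responds strongly to the loss of one carbon. The earlier step, a 3.0-fold lower number from compound 1 to compound 2 (0.48 log units; beyond the scatter), concerned a different part of the molecule and gave no such information about this chain. For compound 3, the result is a limit and not a number: the limit of > 10000 nM in this assay, at which 1 of the 3 values shown sits.

The compounds shown leave open how far the number would move with a longer chain or a cyclopropyl group in place of the isobutyl group, and so whether the isobutyl group is the best choice here. They also leave open whether methoxy in place of methyl on the aromatic carbon would lower the number with the propylcarbonyl group as it does with the isobutylcarbonyl group.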